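Swapping the trimethoxyphenyl arm of compound 1

This account rests on a few compounds, and the source may have more. Where it says the series, first, only, none or still open, it means among the compounds named here.

Compound 1 `COc1cc(/C=C/C(=O)Nc2cc3c(Nc4ccc(F)c(Cl)c4)ncnc3cc2O[C@H]2CCOC2)cc(OC)c1OC` is the reference point of this small series. In a functional assay on A549 cells (Homo sapiens) for cytotoxicity, read by MTT assay, with a stated time of 72 h (on this read-out lower numbers stand for stronger inhibition and higher numbers for weaker inhibition), compound 1 gives 4150 nM, the lowest of the two numbers reported so far. Compound 2 `COc1ccc(/C=C/C(=O)Nc2cc3c(Nc4ccc(F)c(Cl)c4)ncnc3cc2OC)c(OC)c1` gives 33300 nM in this assay, a clearly higher number that lies beyond the usual scatter. Compound 3 `COc1cc2ncnc(Nc3ccc(F)c(Cl)c3)c2cc1NC(=O)/C=C/c1cc(OC)c(OC)c(OC)c1` is recorded in this assay as "not active" (no number reported), without a number attached, so it offers no quantitative anchor.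

Compound 4 `O=C(/C=C/c1ccc(Br)cc1)Nc1cc2c(Nc3ccc(F)c(Cl)c3)ncnc2cc1O[C@H]1CCOC1` has not yet been measured. It differs from compound 1 in a single place: 4-bromophenyl in place of 3,4,5-trimethoxyphenyl on a double-bonded chain carbon bound to a double-bonded chain carbon. For the measured compounds named here, no measured pair in the set isolates this change, so the size of the step has no precedent here. The two compounds with numbers both keep the methoxy-bearing aryl group, and compound 3 shows that keeping the 3,4,5-trimethoxyphenyl does not by itself guarantee a measurable number.

With that in mind, compound 4 is expected to show a modest weakening, a step of a 1.7-fold higher number from compound 1 to compound 4 (0.23 log units; within the scatter), which may still fall close to the scatter. The estimate for compound 4 in this assay is 7000 nM, with a likely range from 1800 nM to 28000 nM.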

Compound 4, half-maximal inhibitory concentration: 35300 nM
Estimate against measurement, compound 4: 5.0-fold (0.70 log units) below; the measured number lies above the stated range.
By their numbers in this assay, from the lowest: compound 1; then compounds 2 and 4 (each within the scatter of the next).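

In this assay, for the compounds shown here, the aryl group on a double-bonded chain carbon bound to a double-bonded chain carbon is not a silent position: 4-bromophenyl in place of 3,4,5-trimethoxyphenyl gives an 8.5-fold higher number from compound 1 to compound 4 (0.93 log units; beyond the scatter), the first step that isolates a single change and one that lies beyond the scatter. Keeping the rest of compound 1 intact therefore does not preserve its number once this aryl group is exchanged, and the exchange replaces a group of 12 heavy atoms and 3 hydrogen-bond acceptors with one of 7 heavy atoms and 0 hydrogen-bond acceptors. No measurement shown here accounts for the size of this step.

This single step cannot separate the loss of the methoxy groups from the entry of the bromine; an unsubstituted phenyl in the same place would divide the two contributions. A dimethylamino group or a carboxylic acid on this aryl ring would test whether the series tolerates substituents other than methoxy and bromine at this position.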